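Benzodioxinyl Replaces Pyridinyl in a Cytotoxicity Series

The source may hold more compounds than are shown below. What is called first, only, known or untested is meant among the compounds shown, and "the series" means these compounds.

The account follows three measured compounds that share one core. Compound 1 `CC(C)N(Cc1cccc(OCCCCCC(=O)O)c1)C(=O)c1ccc(-c2ccoc2)cc1` was tested in an ADME assay on HEK293 cells (Homo sapiens) for cytotoxicity, read by CellTiter-Glo and resazurin assay, with a stated time of 72 h (on this read-out lower numbers stand for an effect already at smaller amounts and higher numbers for an effect only at larger amounts of compound), and gave > 26000 nM, which is a limit of the assay rather than a number. Compound 2 `CC(C)N(Cc1cccc(OCCCCCC(=O)O)c1)C(=O)c1ccc(-c2ccco2)cc1` differs from compound 1 by furan-2-yl in place of furan-3-yl on an aromatic carbon. In this assay compound 2 likewise reaches only the limit > 26000 nM. The step that the two limits leave unreadable from compound 1 to compound 2 is therefore not readable. Compound 3 `CCOC(=O)CCCCCOc1cccc(CN(C(=O)c2ccc(-c3cccnc3)cc2)C(C)C)c1` carries pyridin-3-yl. In this assay compound 3 also stops at the limit > 26000 nM. Thus compound 3 stands where every value shown stands, at the limit of > 26000 nM in this assay, at which 3 of the 3 values shown sit, and no step among the measured compounds can be sized.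

Compound 4 `CCOC(=O)CCCCCOc1cccc(CN(C(=O)c2ccc(-c3ccc4c(c3)OCCO4)cc2)C(C)C)c1` differs from compound 3 by 2,3-dihydro-1,4-benzodioxin-6-yl in place of pyridin-3-yl on an aromatic carbon. Within the data shown here, no measured step bears on this change, and none of the three values is a number. The writer therefore expects no step beyond the scatter, estimating a step that the limit leaves unreadable from compound 3 to compound 4. For compound 4 in this assay the expected value is 30000 nM, with a range from 12000 nM to 80000 nM, most likely reported again only as a limit.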

Compound 4, half-maximal effective concentration: > 24400 nM
Compound 4: only a limit was reported; the forecaster's own chance of this, stated with the estimate: 85%; the middle value is on the limit's open side.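

In this assay compound 3 and compound 4 each gave only a limit and not a number, and the step between them cannot be read. The compounds shown leave open whether any of them has a measurable effect on these cells, with pyridin-3-yl, 2,3-dihydro-1,4-benzodioxin-6-yl or either furan.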